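Methylsulfonyl side chains: working notes toward compound 3

The source may report more compounds than this note shows. Statements on the series, on what has been measured and on what is new or still open speak of the compounds shown alone.

Measured so far in a physicochemical assay for solubility, in phosphate buffer, measured as kinetic solubility, with a stated time of 1 h, at pH 7.4; on this read-out higher numbers stand for higher solubility and lower numbers for lower solubility (two compounds):
- compound 1 `CC(C)(c1cc([C@@]23CCOC[C@@H]2C3)nc(-c2cccc(O)c2)n1)S(C)(=O)=O` gives 148 ug/mL
- compound 2 `CS(=O)(=O)Cc1cc([C@]23CCOC[C@H]2C3)nc(-c2cccc(O)c2)n1` gives 75 ug/mL

In this assay, within the data shown here, compound 2 at 75 ug/mL stands within the usual scatter of compound 1 at 148 ug/mL, so these two numbers set no order between the compounds.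

The next compound is compound 3 `CC(C)(c1cc([C@]23CCOC[C@H]2C3)nc(-c2cccc(O)c2)n1)S(C)(=O)=O`, which differs from compound 2 in one place: 1-methyl-1-(methylsulfonyl)ethyl in place of (methylsulfonyl)methyl on an aromatic carbon. That is 1-methyl-1-(methylsulfonyl)ethyl in place of (methylsulfonyl)methyl on an aromatic carbon. Among the measured compounds shown here, no measured pair isolates this change. For the measured compounds named here, the only guide is compound 1, which carries the same entering group on the shared core drawn in the opposite hand and gives 148 ug/mL in this assay. On that single number, compound 3 is expected to fall close to compound 1. The expected change is a 1.9-fold higher number from compound 2 to compound 3 (0.27 log units; within the scatter), a small rise not clearly beyond the scatter.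

For compound 3 the estimated value is 140 ug/mL, with an expected range from 70 ug/mL to 280 ug/mL in this assay (estimate only)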

Compound 3, solubility: 135 ug/mL
The estimate for compound 3 lay 1.0-fold (0.02 log units) above the measured number; the range from low to high includes it.
By their numbers in this assay, from the lowest: compounds 2, 3 and 1 (each within the scatter of the next).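

In this assay the change from (methylsulfonyl)methyl to 1-methyl-1-(methylsulfonyl)ethyl on the aromatic carbon now has a matched pair, which gives a 1.8-fold higher number from compound 2 to compound 3 (0.26 log units; within the scatter), so at this position the change sets no order between the two compounds. The hand of the shared core can now also be read on its own, through a 1.1-fold lower number from compound 1 to compound 3 (0.04 log units; within the scatter), so inverting both stereocentres likewise sets no order on this read-out. Among these compounds, the side chain and the hand are thus separated for the first time, and the second comparison involves nothing other than the drawn hand: the fact that compounds 1 and 3 differ only in the configuration as drawn.

From the compounds shown here alone, all three compounds carry a methylsulfonyl side chain at this position and lie within the scatter of their neighbours, so it remains open whether an amine, a carboxylic acid or a longer chain in that place would move the number beyond the scatter. Going by these compounds, whether the change from (methylsulfonyl)methyl to 1-methyl-1-(methylsulfonyl)ethyl reads the same in the hand of compound 1 also remains open.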